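The source may hold more compounds than are shown below. What is called first, only, known or untested is meant among the compounds shown, and "the series" means these compounds.

In a functional assay on MCF7 cells (Homo sapiens) for inhibition, read by fluorescence, with a stated time of 72 h (on this read-out higher numbers stand for weaker inhibition of growth and lower numbers for stronger inhibition of growth), compound 1 (`CCCCCCn1cnc2c(Nc3cc(OC)cc(OC)c3)nc(N[C@H]3CC[C@H](N)CC3)nc21`) gives 3500 nM and compound 2 (`CCCCn1cnc2c(Nc3cc(OC)cc(OC)c3)nc(N[C@H]3CC[C@H](N)CC3)nc21`) gives 4500 nM. Within the data shown here, these are the only two numbers at hand, and they lie within the scatter of each other, so compound 2 stands level with compound 1. Among the measured compounds shown here, the one measured step, a 1.3-fold higher number from compound 1 to compound 2 (0.11 log units; within the scatter), sits on the saturated chain and stays within the scatter.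

Compound 3 (`CCCCn1cnc2c(Nc3ccccc3)nc(N[C@H]3CC[C@H](N)CC3)nc21`) differs from compound 2 elsewhere, with phenyl in place of 3,5-dimethoxyphenyl on a nitrogen on an aromatic ring. For the measured compounds named here, no measured step touches this place, so the data give neither a size nor a direction for the change, and the chain step offers only a weak guide. The expected step in this assay is a 1.3-fold higher number from compound 2 to compound 3 (0.12 log units; within the scatter), which means no change beyond the scatter is expected, though with wide uncertainty. For compound 3 the estimated value is 6000 nM, with an expected range from 2000 nM to 18000 nM.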

Compound 3, concentration for 50% growth inhibition: 2200 nM
Compound 3: the middle estimate sits 2.7-fold (0.44 log units) above what was measured; the measured number falls inside the stated range.
By their numbers in this assay, from the lowest: compounds 3, 1 and 2 (each within the scatter of the next, the first and the last beyond it).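

Putting phenyl in place of 3,5-dimethoxyphenyl on a nitrogen on an aromatic ring gives a 2.0-fold lower number from compound 2 to compound 3 (0.31 log units; beyond the scatter) in this assay, so this place, unlike the saturated chain with its step of a 1.3-fold higher number from compound 1 to compound 2 (0.11 log units; within the scatter), moves the number beyond the scatter, though only modestly. The direction also shows that the two methoxy groups are not required for this level of growth inhibition, since the plain phenyl, with fewer heavy atoms and no hydrogen-bond acceptors, gives the lower number. Nothing available explains this shift.

From the compounds shown here alone, it remains open whether a single methoxy group would give the same number, and what a chloro, hydroxyl or amino group on the phenyl would do. Going by these compounds, whether the step would carry over to a compound with a longer chain also remains unknown.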